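Hydroxy for chloro on the pendant phenyl ring

A few compounds are considered here, and "the series" means these few. Any claim that something is new, unique, unknown or untested is made for them only; others in the source may bear on it.

Working notes on a small set of pyrimidine-quinazolinone thioacetamides tested for paw-edema inhibition. Compound 1 `N#Cc1c(-c2ccc(Cl)cc2)nc(SCC(=O)Nn2c(COc3ccc(Cl)cc3Cl)nc3ccccc3c2=O)[nH]c1=O` and compound 2 `N#Cc1c(-c2ccc(O)cc2)nc(SCC(=O)Nn2c(COc3ccc(Cl)cc3Cl)nc3ccccc3c2=O)[nH]c1=O` share one core; compound 3 `N#Cc1c(Nc2ccc(Cl)cc2)nc(SCC(=O)Nn2c(COc3ccc(Cl)cc3Cl)nc3ccccc3c2=O)nc1-c1ccc(Cl)cc1` and the unmeasured compound 4 `N#Cc1c(Nc2ccc(O)cc2)nc(SCC(=O)Nn2c(COc3ccc(Cl)cc3Cl)nc3ccccc3c2=O)nc1-c1ccc(Cl)cc1` share another. How the two cores differ is not broken down here.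

In a functional assay on the whole organism (strain albino) for inhibition, with Rattus norvegicus as the target, read by paw edema, with stated times of 1 h and 2 h, at a dose of 100 mg/kg by the oral route (a higher number here means more inhibition at the dose given (going by the name of the read-out), a lower number less inhibition), compound 1 gives 64.9%. Compound 2 differs from compound 1 by hydroxy in place of chloro on an aromatic carbon, and in this assay compound 2 gives 68.4%; the step of a number 3.5 percentage points higher from compound 1 to compound 2 (within the scatter) is within the scatter, so the two values cannot be told apart. In this assay compound 3 gives 61.4%, which sits within the scatter of both compound 1 and compound 2.

Compound 4 differs from compound 3 by hydroxy in place of chloro on an aromatic carbon. The place lines of the two changes read the same word for word, so this is taken as the same change already seen from compound 1 to compound 2. On that basis the step to compound 4 is expected to be small: the estimated step of a number 3.6 percentage points higher from compound 3 to compound 4 (within the scatter) rests on the measured step of a number 3.5 percentage points higher from compound 1 to compound 2 (within the scatter), which was within the scatter. The expectation is that compound 4 in this assay gives 65%, with a likely range from 55% to 75%. Two compounds make a thin base, and the estimate carries that uncertainty.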

Compound 4, a percentage reported as inhibition, in the whole organism at one dose (the size of the read-out at that dose, not a potency): 91.2%
Compound 4: middle estimate off by 26.2 percentage points, on the low side; the measured number lies above the stated range.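

In this assay, hydroxy in place of chloro gives a number 29.8 percentage points higher from compound 3 to compound 4 (beyond the scatter), and this change does not carry over in size from one core to the other: the same change on two cores in this assay, a number 3.5 percentage points higher (within the scatter) from compound 1 to compound 2 and a number 29.8 percentage points higher (beyond the scatter) from compound 3 to compound 4, 26.3 percentage points apart, beyond the scatter of two such steps

For these two pairs, then, the step measured on the core of compound 1 is no reliable guide to the step on the core of compound 3, and the size of the change has to be read on each core separately. For the compounds shown here, this does not show which of the differences between the two cores goes with the larger step, whether the (4-chlorophenyl)amino group in place of the 4-chlorophenyl group or something else, and with only two pairs it sets no rule for the series; the read-out also gives the size of the inhibition at one dose, not a potency.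

The compounds shown leave open whether the high number of compound 4 is specific to hydroxy or would also appear with a methoxy or an amine at the same place on the (4-hydroxyphenyl)amino group. Also open, going by these compounds, is what hydroxy would do in place of chloro on the remaining 4-chlorophenyl group of compound 4.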